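Replacing propa-1,2-dien-1-yl with propyl on a shared core

A few compounds are considered here, and "the series" means these few. Any claim that something is new, unique, unknown or untested is made for them only; others in the source may bear on it.

In a functional assay on aorta (Rattus norvegicus, strain Sprague-Dawley) for inhibition (a lower number here means that less compound is needed, a higher number that more compound is needed for the effect), compound 1 `C#CCOc1cc2c(c3c1C[C@@H]1[C@@H](C)CO[C@]1(C)O3)C[C@@H]1[C@@H](C)CO[C@]1(C)O2` gives 23000 nM and compound 2 `C=C=CCOc1cc2c(c3c1C[C@@H]1[C@@H](C)CO[C@]1(C)O3)C[C@@H]1[C@@H](C)CO[C@]1(C)O2` gives 12000 nM on the same core. Among the compounds with values here, compound 2 therefore stands level with compound 1, the only other measured compound, since the one measured step is a 1.9-fold lower number from compound 1 to compound 2 (0.28 log units; within the scatter) and lies within the scatter.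

Compound 3 `CCCCOc1cc2c(c3c1C[C@@H]1[C@@H](C)CO[C@]1(C)O3)C[C@@H]1[C@@H](C)CO[C@]1(C)O2` keeps the core and alters the chain on the ether oxygen: propyl in place of propa-1,2-dien-1-yl on a saturated chain carbon bound to an oxygen on an aromatic ring (in words, propyl in place of propa-1,2-dien-1-yl on a saturated chain carbon bound to an oxygen on an aromatic ring). Within the data shown here, no measured compound carries a propyl group at this place, so the evidence is indirect and thin. Among the measured compounds shown here, the only guide is the change that led to compound 2, which amounted to a 1.9-fold lower number from compound 1 to compound 2 (0.28 log units; within the scatter) and did not leave the scatter. A step beyond the scatter is therefore not expected in this assay. The expected step is a 1.3-fold higher number from compound 2 to compound 3 (0.10 log units; within the scatter) and its direction remains uncertain. For compound 3 the estimated value is 15000 nM with an expected range from 5000 nM to 45000 nM in this assay.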

Compound 3, half-maximal effective concentration: 111000 nM
For compound 3 the middle estimate is 7.4-fold (0.87 log units) below the measured one; measured number above the stated range.
By their numbers in this assay, from the lowest: compounds 2 and 1 (each within the scatter of the next); then compound 3.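

Within the data shown here, the saturated chain carbon bound to an oxygen on an aromatic ring proves sensitive to the nature of its substituent in this assay: with 3 carbon atoms both leaving and entering, propyl in place of propa-1,2-dien-1-yl gives a 9.3-fold higher number from compound 2 to compound 3 (0.97 log units; beyond the scatter) and is the first change to leave the scatter. Propyl in place of ethynyl points the same way, with a 4.8-fold higher number from compound 1 to compound 3 (0.68 log units; beyond the scatter), so compound 3 needs more compound than either compound 1 or compound 2, while those two remain within the scatter of each other. The separation among these three compounds therefore lies between propyl and the other two groups, not between ethynyl and propa-1,2-dien-1-yl, and nothing in the data shown accounts for the size of these steps.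

The compounds shown leave open where a group with a single double bond, such as prop-1-enyl, would fall relative to propyl and propa-1,2-dien-1-yl at this place. They also leave open whether a longer chain such as pentyl, or a chain ending in an amine or a carboxylic acid, would sit with compound 3 or with compound 1 and compound 2.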